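The compounds below may be only part of what the source reports. "The series", "measured", "known", "first", "only" and "open" are said of these compounds alone.

Compound 1 `Oc1[nH]nc2nnc(-c3ccccc3)c(-c3ccccc3)c12`: > 100000 nM, a limit of the assay.
Compound 2 `Nc1[nH]nc2nnc(-c3ccccn3)c(-c3ccccn3)c12`: 73000 nM.
Compound 3 `Nc1[nH]nc2nnc(-c3ccc(-c4ccccc4)cc3)c(-c3ccc(-c4ccccc4)cc3)c12`: > 100000 nM, a limit of the assay.

The measurements come from a functional assay on HT-29 cells (Homo sapiens) for cytotoxicity; a lower number here means a stronger inhibitor, a higher number a weaker inhibitor. Compound 1 stands at the limit of this assay, with no number of its own; the same holds for compound 3, so that the limit of > 100000 nM in this assay, at which 2 of the 3 values shown sit, marks where two of the three values sit. Compound 2 alone returns a number, and a weak one. Among the measured compounds shown here, no step between two measured compounds that differ in a single place exists in this set, so the step to compound 4 has no measured counterpart to lean on.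

Compound 4 `CCNC(=O)Nc1[nH]nc2nnc(-c3ccccc3)c(-c3ccccc3)c12` is obtained from compound 1 by the change ((ethylcarbamoyl)amino in place of hydroxy on an aromatic carbon). Because compound 1 sits only at the limit > 100000 nM, the size of the step cannot be read from the shown numbers. The expectation is a modest gain at best, and the step from compound 1 to compound 4 is estimated as an at least 1.6-fold lower number from compound 1 to compound 4 (0.22 log units; that floor lies within the scatter). Compound 4 is thus expected to give about 60000 nM in this assay, within 15000 nM to 150000 nM.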

Compound 4, half-maximal inhibitory concentration: > 100000 nM
Compound 4: a limit, no number; the forecaster's own chance of this, stated with the estimate: 45%; middle value at least 1.6-fold (0.22 log units) from the limit.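

Compound 4 gives > 100000 nM in this assay, a limit of the assay. Among the compounds shown here, compound 1 stands at a limit as well, so no step between compound 1 and compound 4 can be read. Most of the values gather at one point: the limit of > 100000 nM in this assay, at which 3 of the 4 values shown sit. The compounds shown leave open whether (ethylcarbamoyl)amino in place of hydroxy changes the number at all in this assay.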